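The source may report more compounds than this note shows. Statements on the series, on what has been measured and on what is new or still open speak of the compounds shown alone.

Compound 1 `CCCCSc1nsnc1C1CN2CCC[C@H]1C2` and compound 2 `CCCCSc1nsnc1[C@H]1CN2CCC[C@@H]1C2` share one core and differ only in how two ring stereocentres are drawn. In a functional assay on the whole organism for inhibition, with Mus musculus as the target (on this read-out higher numbers stand for an effect only at larger amounts of compound and lower numbers for an effect already at smaller amounts), compound 1 gives 0.045 mg/kg, the higher of the two numbers; compound 2 gives 0.012 mg/kg, and the step of a 3.8-fold lower number from compound 1 to compound 2 (0.57 log units; beyond the scatter) goes with that difference in drawing (the fact that one of compounds 1 and 2 is drawn with a defined configuration and the other without, at the place where they differ). Compound 3 `CCCCCSc1nsnc1C1CN2CCC[C@H]1C2` keeps the drawing of compound 1 and alters the chain: methyl in place of hydrogen on a saturated chain carbon, four bonds along the chain from a sulfur. For the measured compounds named here, no measured step touches the chain, so no shift beyond the scatter is expected: no change at the digits printed from compound 1 to compound 3 (within the scatter). Compound 3 is estimated at 0.045 mg/kg, with a range from 0.015 mg/kg to 0.14 mg/kg.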

Compound 3, dose for half-maximal effect: 0.054 mg/kg
Compound 3: middle estimate off by 1.2-fold (0.08 log units), on the low side, and the stated range covers the measured number.
By their numbers in this assay, from the lowest: compound 2; then compounds 1 and 3 (each within the scatter of the next).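

Methyl in place of hydrogen on a saturated chain carbon, four bonds along the chain from a sulfur, is the first change to the chain here. The step (a 1.2-fold higher number from compound 1 to compound 3 (0.08 log units; within the scatter)) shows that this assay tolerates this added methyl at this position. No available evidence gives a reason for this result.

Going by these compounds, whether a longer chain such as hexyl, or an amine at this position, would be tolerated as well remains open. So does whether the same methyl would have as little effect on the stereo drawing of compound 2.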